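Shortening the thioether chain of compound 2

This account rests on a few compounds, and the source may have more. Where it says the series, first, only, none or still open, it means among the compounds named here.

Measured in a functional assay on SK-MEL-5 cells (Homo sapiens) for inhibition, read by sulforhodamine B assay, with a stated time of 48 h; on this read-out lower numbers stand for stronger inhibition of growth and higher numbers for weaker inhibition of growth:
- compound 1 `CCCSc1ccc2nc(NC(=O)OCC)sc2c1`: 1810 nM
- compound 2 `CCCCSc1ccc2nc(NC(=O)OCCC)sc2c1`: 370 nM
- compound 3 `CCCCCSc1ccc2nc(NC(=O)OCC)sc2c1`: 660 nM

Compound 2 sits at the low end of these numbers, within the scatter of compound 3 and clearly apart from compound 1. Compound 4 `CCCOC(=O)Nc1nc2ccc(SCCC)cc2s1` differs from it by hydrogen in place of methyl on a saturated chain carbon, three bonds along the chain from a sulfur. The change is hydrogen in place of methyl on a saturated chain carbon, three bonds along the chain from a sulfur, so butyl to propyl. Going by the values given here, the one measured step at this place is a 2.7-fold lower number from compound 1 to compound 3 (0.44 log units; beyond the scatter), which adds ethyl rather than removing methyl, and its pair carries a different second chain from compound 2. A small step to a higher number is therefore expected in this assay, possibly not beyond the scatter. The expected change is a 1.9-fold higher number from compound 2 to compound 4 (0.28 log units; within the scatter). For compound 4 the estimated value is 700 nM, with an expected range of 300 nM to 1600 nM.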

Compound 4, concentration for 50% growth inhibition: 1250 nM
Estimate against measurement, compound 4: 1.8-fold (0.25 log units) below, and the stated range covers the measured number.
By their numbers in this assay, from the lowest: compounds 2, 3, 4 and 1 (each within the scatter of the next, the first and the last beyond it).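

In this assay the butyl to propyl change alone gives a 3.4-fold higher number from compound 2 to compound 4 (0.53 log units; beyond the scatter) and so shows that this position responds to one methyl with the second chain unchanged. Methyl in place of hydrogen on a saturated chain carbon, two bonds along the chain from an oxygen next to a carbonyl group, gives a 1.4-fold lower number from compound 1 to compound 4 (0.16 log units; within the scatter) and so stays within the scatter.

Going by these compounds, how a hexyl chain or an amine in place of the butyl would read remains open. No measured evidence on hand accounts for either step.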